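This account rests on a few compounds, and the source may have more. Where it says the series, first, only, none or still open, it means among the compounds named here.

In an ADME assay on HepG2 cells (Homo sapiens) for cytotoxicity, read by MTT assay, with a stated time of 72 h (a lower number here means that less compound is tolerated, a higher number that more compound is tolerated), compound 2 `O=[N+]([O-])c1c(CS(=O)(=O)c2ccccc2)nc2c(-c3ccncc3)cc(Cl)cn12` gives > 50000 nM as a limit and not as a number. Compound 1 `O=[N+]([O-])c1c(CS(=O)(=O)c2ccccc2)nc2c(-c3ccc(F)cc3)cc(Cl)cn12` gives > 15600 nM in this assay and this too is a limit. Among the compounds with values here, compound 2 therefore has no exact half-maximal cytotoxic concentration to start from, and neither does the only other compound measured so far.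

The change to compound 3 `O=[N+]([O-])c1c(CS(=O)(=O)c2ccccc2)nc2c(-c3cccs3)cc(Cl)cn12` is thiophen-2-yl in place of pyridin-4-yl on an aromatic carbon and in short puts thiophen-2-yl in place of pyridin-4-yl on an aromatic carbon. Within the data shown here, the one measured step that bears on this swap is a step that the two limits leave unreadable from compound 1 to compound 2 in which pyridin-4-yl replaced 4-fluorophenyl on an aromatic carbon. That step has no readable size or direction, so it offers nothing firm to carry over to the new group. With so little to go on, no step beyond the usual scatter is expected in this assay and no direction can be named. The expected step is an at least 1.6-fold lower number from compound 2 to compound 3 (0.22 log units; that floor lies within the scatter) and it is only an estimate. For compound 3 the estimated value is 30000 nM with an expected range from 10000 nM to 60000 nM and the assay may well report only a limit again.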

Compound 3, half-maximal cytotoxic concentration: > 3900 nM
Compound 3 gave a limit, no number; the forecaster's own chance of this, stated with the estimate: 75%; the middle value does not contradict the limit.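

In this assay compound 3 gives > 3900 nM, which is a limit and not a number. Within the data shown here, with compound 1, compound 2 and compound 3 all reported as limits, no step between them can be read. From the compounds shown here alone, whether 4-fluorophenyl, pyridin-4-yl and thiophen-2-yl differ at all in the half-maximal cytotoxic concentration, and in which direction, stays open.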